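Ring-Nitrogen Methylation Across Two Closely Related Cores

The source may hold more compounds than are shown below. What is called first, only, known or untested is meant among the compounds shown, and "the series" means these compounds.

Of the compounds shown here, three built on a shared core have been tested in a functional assay on HeLa cells (Homo sapiens) for inhibition, read by MTT assay, with a stated time of 24 h; a lower number here means a stronger inhibitor, a higher number a weaker inhibitor. Compound 1 `CO/N=C1\C[C@@H](c2ccc(F)cc2)N[C@@H](c2ccc(F)cc2)[C@@H]1C` gives 49200 nM in this assay. Compound 2 `CO/N=C1\C[C@@H](c2ccc(C)cc2)N[C@@H](c2ccc(C)cc2)[C@@H]1C` gives 81600 nM in this assay; how its core differs from that of compound 1 is not broken down here. Compound 3 `CO/N=C1\C[C@@H](c2ccc(F)cc2)N(C)[C@@H](c2ccc(F)cc2)[C@@H]1C` gives 40700 nM in this assay.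

Compound 3 arises from compound 1 by a single change, (methyl in place of hydrogen on an amine nitrogen in a ring). In this assay this change produced a 1.2-fold lower number from compound 1 to compound 3 (0.08 log units; within the scatter), so the two numbers cannot be told apart. The values of compound 1 and compound 2 also lie within the usual scatter of each other, as do those of compound 2 and compound 3.

Compound 4 `CO/N=C1\C[C@@H](c2ccc(C)cc2)N(C)[C@@H](c2ccc(C)cc2)[C@@H]1C` has not yet been measured. It arises from compound 2 by methyl in place of hydrogen on an amine nitrogen in a ring. Within the data shown here, this is the same kind of change as the one leading to compound 3, but the surroundings are not identical: in compound 2 the nitrogen sits next to two ring atoms that each bear a 4-methylphenyl group, whereas in compound 1 they each bear a 4-fluorophenyl group.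

The step expected in this assay is a 1.2-fold lower number from compound 2 to compound 4 (0.08 log units; within the scatter). This expectation rests on the earlier step, a 1.2-fold lower number from compound 1 to compound 3 (0.08 log units; within the scatter), which stayed within the scatter. Compound 4 is therefore expected to give about 68000 nM in this assay. Its likely range is estimated to run from 30000 nM to 160000 nM.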

Compound 4, half-maximal inhibitory concentration: 47700 nM
The estimate for compound 4 lay 1.4-fold (0.15 log units) above the measured number, and the stated range covers the measured number.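

In this assay, methyl in place of hydrogen on the amine nitrogen in the ring of the core with two 4-methylphenyl groups gave a 1.7-fold lower number from compound 2 to compound 4 (0.23 log units; within the scatter), so this step cannot be told apart from repeat-measurement noise. Set beside the earlier step on the core with two 4-fluorophenyl groups, it shows no detectable difference in how the change behaves on the two cores: the same change on two cores in this assay, a 1.2-fold lower number (0.08 log units; within the scatter) from compound 1 to compound 3 and a 1.7-fold lower number (0.23 log units; within the scatter) from compound 2 to compound 4, 1.4-fold (0.15 log units) apart, within the scatter of two such steps. Among these compounds, this agreement means only that the change gave no measurable shift on either core; it does not show that the methyl has a real effect, and it cannot show that a larger effect would carry from one core to the other, nor does it extend beyond these two cores.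

The compounds shown leave open whether a larger group on the same nitrogen, such as a longer chain like propyl, a benzyl group or an acetyl group, would produce a step beyond the scatter, and whether that step would match on both cores. They also leave open how the same change behaves when the aryl groups carry something else, such as a methoxy group or a chlorine atom.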